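Iodo for furan-3-yl on the shared core: compound 3

The source may hold more compounds than are shown below. What is called first, only, known or untested is meant among the compounds shown, and "the series" means these compounds.

Working notes on the series. Compound 1 `COc1ncnc2c1c(I)cn2[C@@H]1O[C@H](CO)[C@@H](O)[C@H]1O` carries iodo and methoxy on the shared core; in a functional assay on K562 cells (Homo sapiens), read by MTT assay, with a stated time of 72 h (on this read-out lower numbers stand for stronger inhibition and higher numbers for weaker inhibition), compound 1 gives 14800 nM. Compound 2 `Cc1ncnc2c1c(-c1ccoc1)cn2[C@@H]1O[C@H](CO)[C@@H](O)[C@H]1O` carries furan-3-yl and methyl instead. For compound 2 this assay reports only a limit, > 20000 nM, so compound 2 stands at the limit of > 20000 nM in this assay, at which 1 of the 2 values shown sits, rather than at a number. Compound 3 `Cc1ncnc2c1c(I)cn2[C@@H]1O[C@H](CO)[C@@H](O)[C@H]1O` is still to be measured in this assay. The change from compound 2 to compound 3 is iodo in place of furan-3-yl on an aromatic carbon. Among the measured compounds shown here, no measured pair in the set differs in this one place, so the size of the step is not known from data; the only anchor is that compound 1, which also carries iodo, gives a measurable number. The step from compound 2 to compound 3 is expected to be an at least 1.6-fold lower number from compound 2 to compound 3 (0.22 log units; that floor lies within the scatter), that is toward a measurable value. Compound 3 is accordingly estimated at 12000 nM, within a range from 4000 nM to 30000 nM.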

Compound 3, half-maximal inhibitory concentration: > 20000 nM
Compound 3 gave a limit, no number; the forecaster's own chance of this, stated with the estimate: 35%; middle value at least 1.6-fold (0.22 log units) away from the limit.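

In this assay compound 3 gives > 20000 nM, which is a limit and not a number. With methyl on the shared core, iodo on this aromatic carbon does not yield a measurable value, and the step between iodo and furan-3-yl cannot be read because compound 2 and compound 3 both rest at the same limit: the limit of > 20000 nM in this assay, at which 2 of the 3 values shown sit. With iodo kept, methyl in place of methoxy gives an at least 1.3-fold higher number from compound 1 to compound 3 (0.13 log units; that floor lies within the scatter), so only a floor is known for this change, and the true size of the step remains undetermined.

The compounds shown leave open whether furan-3-yl paired with methoxy would give a number. They also leave open whether an amine in place of methoxy, with iodo kept, would shift the value of compound 1.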